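Adding Bromine to the Core: Another Limit Expected

A few compounds are considered here, and "the series" means these few. Any claim that something is new, unique, unknown or untested is made for them only; others in the source may bear on it.

Compound 3 `C=C1C[C@]23C[C@@]1(O)CC[C@H]2c1ccc(O)c(C)c1[C@@H]3Cn1cc(-c2ccccc2)nn1` was tested in a functional assay on SW480 cells (Homo sapiens) for cytotoxicity, read by MTT assay, with a stated time of 4 days; on this read-out higher numbers stand for weaker inhibition and lower numbers for stronger inhibition. In this assay compound 3 reaches only the limit of > 20000 nM and gives no number. Compound 2 `C=C1C[C@]23C[C@@]1(O)CC[C@H]2c1ccc(O)c(C)c1[C@@H]3Cn1cc(-c2ccc(Br)cc2)nn1` likewise reaches only the limit of > 20000 nM. The step that the two limits leave unreadable from compound 2 to compound 3 therefore cannot be sized. Compound 1 `C=C1C[C@]23C[C@@]1(O)CC[C@H]2c1cc(Br)c(O)c(C)c1[C@@H]3Cn1cc(-c2ccc(OC)cc2)nn1`, which carries bromine on the shared core, also gives only the limit of > 20000 nM. Compound 4 `C=C1C[C@]23C[C@@]1(O)CC[C@H]2c1cc(Br)c(O)c(C)c1[C@@H]3Cn1cc(-c2ccccc2)nn1` differs from compound 3 by bromo in place of hydrogen on an aromatic carbon. Among the measured compounds shown here, no measured step of readable size bears on this change; the only evidence is the limit of > 20000 nM in this assay, at which 3 of the 3 values shown sit. The step in this assay is expected to be a step that the limit leaves unreadable from compound 3 to compound 4, a reported limit rather than a number. The estimate for compound 4 is 30000 nM, with a range from 15000 nM to 100000 nM.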

Compound 4, half-maximal inhibitory concentration: > 20000 nM
Compound 4: a limit, no number (the forecaster's own chance of this, stated with the estimate: 85%); the middle value is on the limit's open side.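

Compound 4 gives only a limit, > 20000 nM, in this assay, and its steps from compound 3 and from compound 1 cannot be read. As far as these compounds go, whether bromo in place of hydrogen on the shared core changes cytotoxicity at all stays open.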